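The source may hold more compounds than are shown below. What is called first, only, known or untested is meant among the compounds shown, and "the series" means these compounds.

Working notes on the series. Compound 1 `O=C(Oc1ccc(-c2cncn2C2CCN(C(=O)c3ccc(Cl)c(C(F)(F)F)c3)CC2)cc1)c1ccccc1` in an assay on HEK293 cells for antagonist activity at P2X purinoceptor 7 (Homo sapiens), read by fluorescence, with a stated time of 2 h (a lower number here means a stronger inhibitor, a higher number a weaker inhibitor), gives only a limit, > 10000 nM. Compound 2 `O=C(c1ccc(Cl)c(C(F)(F)F)c1)N1CCC(n2cncc2-c2ccc(OS(=O)(=O)c3cccc([N+](=O)[O-])c3)cc2)CC1` in this assay gives 249 nM. Within the data shown here, the one measured step, an at least 40-fold lower number from compound 1 to compound 2 (1.60 log units; beyond the scatter), rests on (the limit of > 10000 nM in this assay, at which 1 of the 3 values shown sits), so its size is a lower bound only. Compound 3 `COc1ccc(C(=O)N2CCC(n3cncc3-c3ccc(OS(=O)(=O)c4cccc5cnccc45)cc3)CC2)cc1OC` in this assay gives 259 nM; this is the higher of the two numbers, but compound 2 sits within the scatter of it, so no order between compound 2 and compound 3 is claimed.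

Compound 4 `CN(C)c1ccc(C(=O)N2CCC(n3cncc3-c3ccc(OS(=O)(=O)c4cccc5cnccc45)cc3)CC2)cc1` has not yet been measured in this assay. Its change from compound 3 is 4-(dimethylamino)phenyl in place of 3,4-dimethoxyphenyl on a carbonyl carbon. Among the measured compounds shown here, no measured step touches this carbonyl position: the single step concerns the group on the phenolic oxygen, not the amide. The only indirect hint is that compound 2 and compound 3, which carry different aryl groups on the same carbonyl, fall within the scatter of one another, so a step of no size beyond the scatter is expected for compound 4, as a 1.2-fold higher number from compound 3 to compound 4 (0.06 log units; within the scatter). Compound 4 is therefore estimated at 300 nM in this assay, within 100 nM to 900 nM.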

Compound 4, half-maximal inhibitory concentration: 0.11 nM
Estimate against measurement, compound 4: 2700-fold (3.44 log units) above; the measured number lies below the stated range.
By their numbers in this assay, from the lowest: compound 4; then compounds 2 and 3 (each within the scatter of the next). At a limit, above all of these: compound 1.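

With the group on the phenolic oxygen unchanged, the aryl group on this carbonyl carbon proves decisive in this assay: 4-(dimethylamino)phenyl in place of 3,4-dimethoxyphenyl gives a 2400-fold lower number from compound 3 to compound 4 (3.37 log units; beyond the scatter). Among these compounds, this is the first measured step at the carbonyl position, as the earlier step concerned only the group on the oxygen, and it shows that the amide aryl group can change the number by a large margin. Nothing measured in the series gives a reason for the size of this step.

From the compounds shown here alone, it remains open whether the step comes from the dimethylamino group itself or from the loss of the two methoxy groups, and a primary amine, a diethylamino group or a lone methoxy group on this aryl ring would help separate these. Also open, going by these compounds, is whether 4-(dimethylamino)phenyl gives a similar step with (3-nitrophenyl)sulfonyl on the oxygen.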